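A Piperidine Ring in Place of Dimethylamino

A few compounds are considered here, and "the series" means these few. Any claim that something is new, unique, unknown or untested is made for them only; others in the source may bear on it.

In a functional assay on A549 cells (Homo sapiens) for antiproliferative activity, read by MTT assay, with a stated time of 48 h (a higher number here means a weaker inhibitor, a lower number a stronger inhibitor), compound 1 (`Cn1c(N)c(-c2nc3ccccc3[nH]2)c2nc(C#N)c(C#N)nc21`) gives > 50000 nM, which is a limit of the assay and not a number. Compound 2 (`CCn1c(N)c(-c2nc3ccccc3[nH]2)c2nc(C#N)c(C#N)nc21`) gives > 50000 nM, again a limit. Among the measured compounds shown here, compound 3 (`CN(C)CCCn1c(N)c(-c2nc3ccccc3[nH]2)c2nc(C#N)c(C#N)nc21`) is the only one with a true number, 10400 nM. Compound 4 (`N#Cc1nc2c(-c3nc4ccccc4[nH]3)c(N)n(CCCN3CCCCC3)c2nc1C#N`) puts piperidin-1-yl in place of dimethylamino on the 3-(dimethylamino)propyl chain: piperidin-1-yl in place of dimethylamino on a saturated chain carbon, three bonds along the chain from an aromatic nitrogen. The nearest evidence is an at least 4.8-fold lower number from compound 1 to compound 3 (0.68 log units; beyond the scatter), and an at least 4.8-fold lower number from compound 2 to compound 3 (0.68 log units; beyond the scatter). Both steps introduced the dimethylamino-bearing chain, which compound 4 retains with a changed end, so no step beyond the scatter is expected in this assay. The estimated step is a 1.2-fold lower number from compound 3 to compound 4 (0.09 log units; within the scatter). Compound 4 is expected at about 8500 nM, with an estimated range of 3500 nM to 25000 nM.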

Compound 4, half-maximal inhibitory concentration: 6110 nM
Compound 4: middle estimate off by 1.4-fold (0.14 log units), on the high side; the range from low to high includes it.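

In this assay, replacing the dimethylamino end of the chain with a piperidin-1-yl ring gives a 1.7-fold lower number from compound 3 to compound 4 (0.23 log units; within the scatter), so the ring keeps the activity seen with the open amine. The ring-bearing chain also separates clearly from the simple alkyl groups, with an at least 8.1-fold lower number from compound 2 to compound 4 (0.91 log units; beyond the scatter) and an at least 8.1-fold lower number from compound 1 to compound 4 (0.91 log units; beyond the scatter). Both of these steps start from a limit of the assay, not a number: the limit of > 50000 nM in this assay, at which 2 of the 4 values shown sit.

Going by these compounds, whether the chain end needs this amine nitrogen remains open. A morpholine ring, a terminal hydroxyl group or a longer chain carrying piperidin-1-yl could each address that question.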